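Methylphenyl in Place of Fluoropyridyl on the Shared Core

The source may hold more compounds than are shown below. What is called first, only, known or untested is meant among the compounds shown, and "the series" means these compounds.

Compound 3 `N#CCCCn1c(Cn2c(=O)n(-c3ccncc3F)c3ccncc32)cc2cc(Cl)ccc21` stands at the upper end of what an ADME assay on HeLa cells (Homo sapiens) for cytotoxicity, read by ATP content, with a stated time of 3 days (on this read-out lower numbers stand for higher toxicity in this test and higher numbers for lower toxicity in this test), reports: compound 3 gives > 50000 nM, which is a limit of the assay and not a number. Compound 1 `CS(=O)(=O)CCCn1c(Cn2c(=O)n(C3CN(S(C)(=O)=O)C3)c3ccncc32)cc2cc(Cl)ccc21` gives > 50000 nM in this assay, again a limit. Compound 2 `N#CCCCn1c(Cn2c(=O)n(-c3ccc(C(=O)NC4CC4)cc3)c3ccncc32)cc2cc(Cl)ccc21` gives > 50000 nM in this assay, likewise a limit. the limit of > 50000 nM in this assay, at which 3 of the 3 values shown sit, describes where all three values sit. Going by the values given here, the one step among them, a step that the two limits leave unreadable from compound 2 to compound 3, is not readable, both of its ends being limits. Compound 4 `Cc1ccc(-n2c(=O)n(Cc3cc4cc(Cl)ccc4n3CCCC#N)c3cnccc32)cc1` differs from compound 3 by 4-methylphenyl in place of 3-fluoropyridin-4-yl on an aromatic nitrogen. Among the compounds with values here, no measured step gives a readable size for a change of this kind, and nothing among the three values points away from the limit. Compound 4 is therefore expected to give 50000 nM, with a range from 20000 nM to 100000 nM. The expected step of a number no higher from compound 3 to compound 4 (the limit leaves the size open) is thus estimated as none beyond the scatter.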

Compound 4, half-maximal cytotoxic concentration: > 50000 nM
Compound 4: no number, only a limit; the forecaster's own chance of this, stated with the estimate: 80%; the middle value sits exactly at the limit.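

With compound 4 also resting on a limit, the steps joining compound 2, compound 3 and compound 4 in this assay cannot be read. The compounds shown leave open whether any change on the shared core would bring a readable number: the limit of > 50000 nM in this assay, at which 4 of the 4 values shown sit.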